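Cytotoxicity limits across the series; estimate for compound 4

A few compounds are considered here, and "the series" means these few. Any claim that something is new, unique, unknown or untested is made for them only; others in the source may bear on it.

Of the compounds shown here, three have been measured in an ADME assay on HEp-2 cells (Homo sapiens) for cytotoxicity, with a stated time of 4 days; a higher number here means that more compound is tolerated, a lower number that less compound is tolerated. Compound 1 `CS(=O)(=O)CCn1c(Cn2c(S(C)(=O)=O)cc3ccccc32)nc2ccccc21` gives > 100000 nM, which is a limit of the assay rather than a number. Compound 2 `CCS(=O)(=O)c1cn(Cc2nc3cc(Cl)ccc3n2CCCS(C)(=O)=O)c2ccccc12` gives > 100000 nM, again a limit. Compound 3 `CC(C)(O)CCn1c(Cn2nc(S(C)(=O)=O)c3ccncc32)nc2cc(Cl)ccc21` gives > 100000 nM, also a limit. All three values sit at the limit of > 100000 nM in this assay, at which 3 of the 3 values shown sit, so no step between measured compounds can be read, and nothing on the numbers shown separates compound 3 from the other two.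

Compound 4 `CS(=O)(=O)c1nn(Cc2nc3cc(Cl)ccc3n2CCC(O)C(F)F)c2cnccc12` has not yet been measured. It differs from compound 3 in one place: 2,2-difluoro-1-hydroxyethyl in place of 1-hydroxy-1-methylethyl on a saturated chain carbon, two bonds along the chain from an aromatic nitrogen. With compound 3 sitting at the limit of > 100000 nM in this assay, at which 3 of the 3 values shown sit, no step beyond the scatter is expected in this assay in either direction. The expected step from compound 3 to compound 4 is a number no higher from compound 3 to compound 4 (the limit leaves the size open). Compound 4 is estimated at 100000 nM, within 30000 nM to 300000 nM, and is most likely to be reported again only as a limit.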

Compound 4, half-maximal cytotoxic concentration: > 100000 nM
Compound 4: no number, only a limit (the forecaster's own chance of this, stated with the estimate: 85%); the middle value lies on the limit itself.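

Compound 4 gives > 100000 nM in this assay as a limit of the assay and not a number. No step from compound 3 to compound 4 can be read because both values are limits: the limit of > 100000 nM in this assay, at which 4 of the 4 values shown sit.

Still open is whether 2,2-difluoro-1-hydroxyethyl and 1-hydroxy-1-methylethyl differ at all in tolerated concentration, since all compounds shown lie at this limit.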